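This account rests on a few compounds, and the source may have more. Where it says the series, first, only, none or still open, it means among the compounds named here.

Measured in a functional assay on NCI/ADR-RES cells (Homo sapiens) for inhibition, read by sulforhodamine B assay, with a stated time of 48 h; on this read-out lower numbers stand for stronger inhibition of growth and higher numbers for weaker inhibition of growth:
Compound 1 `CC1(/C=C/c2ccccc2C(F)(F)F)C=CC(=O)O1`: 12200 nM
Compound 2 `CC1(/C=C/c2ccc(F)cc2)C=CC(=O)O1`: 25700 nM

Of these two numbers, compound 2 has the higher, at 25700 nM, and compound 1 lies lower by a gap just beyond the usual scatter. Compound 3 `COc1ccc(/C=C/C2(C)C=CC(=O)O2)cc1` has not yet been measured. It carries methoxy in place of fluoro on an aromatic carbon. Within the data shown here, no step between measured compounds that differ in one place is available, so the expectation rests only on the two values, which differ in their aromatic substituents yet stay close. No step beyond the scatter is expected in this assay, with at most a slight drift towards a lower number. The estimate for compound 3 is 21000 nM, with an expected range of 9000 nM to 50000 nM. The expected change is a 1.2-fold lower number from compound 2 to compound 3 (0.09 log units; within the scatter).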

Compound 3, concentration for total growth inhibition: > 1000000 nM
Compound 3 was reported as a limit; the forecaster's own chance of this, stated with the estimate: 10%; at least 47-fold (1.67 log units) between middle value and limit.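

In this assay, the group on this aromatic carbon, para to a group of 9 heavy atoms, matters a great deal: methoxy in place of fluoro gives an at least 38-fold higher number from compound 2 to compound 3 (1.59 log units; beyond the scatter) on this read-out. The result for compound 3 is a limit of the assay and not a number: the limit of > 1000000 nM in this assay, at which 1 of the 3 values shown sits. Among these compounds, compound 1 and compound 2 differ in more than one place, so only this step isolates a single change at this position, and it shows that growth inhibition here does not tolerate every small substituent.

On these data alone, whether this loss is specific to methoxy or would also appear with a hydroxyl, an amine or a longer chain such as ethoxy on the same carbon stays open. The compounds shown also leave open how the unsubstituted aromatic ring would compare.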